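Extending a methoxy group to ethoxy

The source may report more compounds than this note shows. Statements on the series, on what has been measured and on what is new or still open speak of the compounds shown alone.

Of the compounds shown here, three sharing one core have been tested so far in a functional assay on MCF7 cells (Homo sapiens) for cytotoxicity, read by MTT assay, with a stated time of 48 h (on this read-out higher numbers stand for weaker inhibition and lower numbers for stronger inhibition), with closely matching results. There compound 1 (`Cc1ccccc1-c1nnc(SCCn2c([N+](=O)[O-])cnc2C)o1`) gives 15800 nM while compound 2 (`Cc1ccc(-c2nnc(SCCn3c([N+](=O)[O-])cnc3C)o2)cc1`) gives 15500 nM and compound 3 (`COc1ccc(-c2nnc(SCCn3c([N+](=O)[O-])cnc3C)o2)cc1`) gives 10600 nM as its result. Compound 3 therefore cannot be told apart from the other two. Each measured move, a 1.0-fold lower number from compound 1 to compound 2 (0.01 log units; within the scatter) and a 1.5-fold lower number from compound 1 to compound 3 (0.17 log units; within the scatter) and a 1.5-fold lower number from compound 2 to compound 3 (0.17 log units; within the scatter) alike, stays inside the normal noise of such measurements.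

Compound 4 (`CCOc1ccc(-c2nnc(SCCn3c([N+](=O)[O-])cnc3C)o2)cc1`) turns the methoxy of compound 3 into ethoxy: methyl in place of hydrogen on a saturated chain carbon bound to an oxygen on an aromatic ring. Within the data shown here, no measured pair shows this exact change. Among the measured compounds shown here, the closest precedent is a 1.5-fold lower number from compound 2 to compound 3 (0.17 log units; within the scatter) where methoxy takes the place of methyl on an aromatic carbon. That step is small, so in this assay no shift beyond the scatter is expected in either direction. The estimate is a 1.0-fold lower number from compound 3 to compound 4 (0.00 log units; within the scatter) and it amounts to no real change. Compound 4 is estimated at 10500 nM (expected range 5500 nM to 19000 nM).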

Compound 4, half-maximal inhibitory concentration: 16600 nM
The estimate for compound 4 lay 1.6-fold (0.20 log units) below the measured number; the measured number falls inside the stated range.
By their numbers in this assay, from the lowest: compounds 3, 2, 1 and 4 (each within the scatter of the next).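

In this assay, among these compounds, lengthening methoxy to ethoxy gives a 1.6-fold higher number from compound 3 to compound 4 (0.19 log units; within the scatter) and offers the first direct look at adding a methyl on a saturated chain carbon bound to an oxygen on an aromatic ring: the extra carbon produces no change that can be separated from the scatter. The wider swap of methyl on an aromatic carbon for ethoxy gives a 1.1-fold higher number from compound 2 to compound 4 (0.03 log units; within the scatter) and is just as unremarkable, so the methyl, methoxy and ethoxy compounds (compound 2, compound 3 and compound 4) cannot be told apart here, and this site has so far tolerated all three groups without a measurable shift. No supporting measurement bears on this result, so this flat picture stands only as an observation.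

From the compounds shown here alone, what remains open is whether the site would stay as flat with a much longer chain such as butoxy, or with a different kind of group such as an amine or a carboxylic acid. Going by these compounds, all four compounds also share a single cell assay, so whether the same flat picture holds in any other test remains unknown.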